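The source may hold more compounds than are shown below. What is called first, only, known or untested is meant among the compounds shown, and "the series" means these compounds.

Measured so far:
Compound 1, `COc1ccc(S(=O)(=O)NCCCNc2nccc(-c3c(-c4cccc(F)c4)nc4sccn34)n2)cc1`, in a functional assay on A-375 cells (Homo sapiens) for cytotoxicity, read by MTT assay; on this read-out higher numbers stand for weaker inhibition and lower numbers for stronger inhibition: 5510 nM
Compound 2, `O=S(=O)(NCCNc1nccc(-c2c(-c3cccc(F)c3)nc3sccn23)n1)c1ccccc1`, in this assay: 11000 nM

Compound 1 carries a methoxy group on the sulfonyl-bearing ring and a propyl chain to the aminopyrimidine, while compound 2 lacks both the methoxy group and one carbon of that chain. In this assay the two numbers lie within the usual scatter of one another, so neither compound can be set apart from the other on this read-out.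

Compound 3, `O=S(=O)(NCCCNc1nccc(-c2c(-c3cccc(F)c3)nc3sccn23)n1)c1ccccc1`, keeps the propyl chain of compound 1 and differs from it in one place: hydrogen in place of methoxy on an aromatic carbon. For the measured compounds named here, no measured pair isolates this change, so its effect can only be guessed from the closeness of compound 1 and compound 2. The expected step, a 1.4-fold higher number from compound 1 to compound 3 (0.13 log units; within the scatter), is small, toward a somewhat weaker inhibition, and not clearly beyond the scatter. Compound 3 is therefore estimated at 7500 nM, in a range from 2500 nM to 22000 nM.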

Compound 3, half-maximal inhibitory concentration: 6600 nM
Compound 3: middle estimate off by 1.1-fold (0.06 log units), on the high side; the measured number falls inside the stated range.
By their numbers in this assay, from the lowest: compounds 1, 3 and 2 (each within the scatter of the next).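

For the methoxy group para to a large group, compound 3 gives the first direct reading: this assay shows a 1.2-fold higher number from compound 1 to compound 3 (0.08 log units; within the scatter) for hydrogen in place of methoxy, so the two cannot be told apart on this read-out. The chain can now also be read alone, and ((phenylsulfonyl)amino)methyl in place of (phenylsulfonyl)amino gives a 1.7-fold lower number from compound 2 to compound 3 (0.22 log units; within the scatter) and so also stays unresolved. No independent measurement is available that would explain either result.

On these data alone, it remains open whether a different group at this ring position, such as a trifluoromethyl, a carboxylic acid or an amine, would move the number beyond the scatter. As far as these compounds go, it is equally open whether a longer chain, such as butyl, would separate from the propyl chain of compound 3 in this assay on this read-out.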